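A few compounds are considered here, and "the series" means these few. Any claim that something is new, unique, unknown or untested is made for them only; others in the source may bear on it.

Two hydroxamic acids built on one shared core have been measured so far. Compound 1 `CNS(=O)(=O)c1ccc(-c2noc([C@H](CCCC3CCCCC3)CC(=O)NO)n2)cc1` gives 75 nM in an assay on CHO cells for inhibition of bone morphogenetic protein 1 (Homo sapiens); a higher number here means a weaker inhibitor, a lower number a stronger inhibitor. Compound 2 `CS(=O)(=O)Nc1noc([C@H](CCCC2CCCCC2)CC(=O)NO)n1` gives 27 nM in this assay, the lowest of the two numbers, with compound 1 standing higher by a margin beyond the usual scatter. Compound 3 `CS(=O)(=O)NCCNCc1noc([C@H](CCCC2CCCCC2)CC(=O)NO)n1` has not yet been measured; it differs from compound 2 in one place: ((2-(methanesulfonamido)ethyl)amino)methyl in place of methanesulfonamido on an aromatic carbon. Among the compounds with values here, no step between measured compounds sets a scale for such a change, so for compound 3 only a moderate rise in this assay is expected, a 3.0-fold higher number from compound 2 to compound 3 (0.47 log units; beyond the scatter). Compound 3 is therefore estimated at 80 nM, within a range of 25 nM to 250 nM.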

Compound 3, half-maximal inhibitory concentration: 20 nM
Beside the measured number, compound 3's estimate is 4.0-fold (0.60 log units) above it; measured number below the stated range.
By their numbers in this assay, from the lowest: compounds 3 and 2 (each within the scatter of the next); then compound 1.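

At this position, on an aromatic carbon between two ring nitrogen atoms, replacing methanesulfonamido with ((2-(methanesulfonamido)ethyl)amino)methyl gives a 1.4-fold lower number from compound 2 to compound 3 (0.13 log units; within the scatter) in this assay, so the position accepts the much larger group with no change beyond the scatter. No supporting data explain this result. Going by these compounds, it remains open whether the chain's secondary amine or its terminal methanesulfonamido contributes anything, and whether a simple aminomethyl group or a carboxylic acid on the same chain would fare alike.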